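The source may report more compounds than this note shows. Statements on the series, on what has been measured and on what is new or still open speak of the compounds shown alone.

In a functional assay on RAW264.7 cells (Mus musculus) for inhibition, with a stated time of 4 days (a higher number here means a weaker inhibitor, a lower number a stronger inhibitor), three compounds have so far been measured:

compound 1 `COc1cc(/C=C/C(=O)c2cccc(-n3cc(C(C)(C)O)nn3)c2)ccc1O`: 19800 nM
compound 2 `COc1cc(/C=C/C(=O)c2cccc(-n3cc(-c4ccc(C)cc4)nn3)c2)ccc1O`: 15400 nM
compound 3 `COc1ccc(-c2cn(-c3cccc(C(=O)/C=C/c4ccc(O)c(OC)c4)c3)nn2)cc1`: 7900 nM

Compound 3 holds the lowest of the three numbers. Its nearest neighbour is compound 2, and the gap a 1.9-fold lower number from compound 2 to compound 3 (0.29 log units; within the scatter) lies within the scatter, so the two cannot be ordered. Against compound 1 the step of a 2.5-fold lower number from compound 1 to compound 3 (0.40 log units; beyond the scatter) is modest and beyond the scatter, whereas the step of a 1.3-fold lower number from compound 1 to compound 2 (0.11 log units; within the scatter) is within it.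

Compound 4 `COc1cc(/C=C/C(=O)c2cccc(-n3cc(-c4cc(F)cc(F)c4)nn3)c2)ccc1O` has not yet been measured. It differs from compound 3 in one place: 3,5-difluorophenyl in place of 4-methoxyphenyl on an aromatic carbon.

Among the measured compounds shown here, the step that bears on this change is the one among the aryl-bearing compounds, a 1.9-fold lower number from compound 2 to compound 3 (0.29 log units; within the scatter), where one substituent on the pendant phenyl was swapped for another and the number moved only within the scatter. Nothing measured speaks to fluorine on that ring, and the data give no basis for a large move in either direction. Compound 4 is therefore expected to show a step of a 1.3-fold higher number from compound 3 to compound 4 (0.10 log units; within the scatter) that stays within the usual scatter. The estimate for compound 4 in this assay is 10000 nM, with a range from 5000 nM to 22000 nM.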

Compound 4, half-maximal inhibitory concentration: 22800 nM
The estimate for compound 4 lay 2.3-fold (0.36 log units) below the measured number; the whole stated range lies below it.
By their numbers in this assay, from the lowest: compounds 3, 2, 1 and 4 (each within the scatter of the next, the first and the last beyond it).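

In this assay, among the compounds shown here, the aryl groups at this position are not all interchangeable: 3,5-difluorophenyl in place of 4-methoxyphenyl gives a 2.9-fold higher number from compound 3 to compound 4 (0.46 log units; beyond the scatter) and is the only step between two aryl-bearing compounds that passes beyond the scatter. The same group in place of 4-methylphenyl gives a 1.5-fold higher number from compound 2 to compound 4 (0.17 log units; within the scatter) and in place of 1-hydroxy-1-methylethyl gives a 1.2-fold higher number from compound 1 to compound 4 (0.06 log units; within the scatter), and neither of these pairs can be ordered, which leaves the 4-methoxyphenyl compound as the only one here set apart from the 3,5-difluorophenyl compound. No measurement available here accounts for the step away from 4-methoxyphenyl.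

The compounds shown leave open whether the difference rests on the methoxy group, on the two fluorines or on both, and a plain phenyl or a phenyl carrying a single fluorine would separate these possibilities. For the compounds shown here, they also leave open how this position responds to groups of another kind, such as a carboxylic acid, an amine or a morpholine in place of the pendant phenyl, as all the numbers so far lie within a narrow band.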